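A few compounds are considered here, and "the series" means these few. Any claim that something is new, unique, unknown or untested is made for them only; others in the source may bear on it.

Measured compounds:
compound 1 `CC(C)OC(=O)N1CCC(Oc2ncnc3c2CCN3c2ccc(S(C)(=O)=O)cc2F)CC1`: 91%
compound 2 `CC(C)OC(=O)N1CCC(Oc2ncnc3c2CCN3c2ccc(C#N)cc2F)CC1`: 134%
compound 3 `CS(=O)(=O)c1ccc(N2CCc3c(OC4CCN(C(=O)OCCF)CC4)ncnc32)c(F)c1`: 86%

These numbers come from a functional assay on CHO-K1 cells with Glucose-dependent insulinotropic receptor (Homo sapiens) as the target, read by a luciferase reporter, with a stated time of 5 h; a higher number here means a larger maximal response, a lower number a smaller maximal response. Compound 3 gives the lowest of the three values, but compound 1 lies within the usual scatter of it, while compound 2 sits well beyond it. Compound 4 `CC(C)S(=O)(=O)N1CCC(Oc2ncnc3c2CCN3c2ccc(S(C)(=O)=O)cc2F)CC1` is not yet measured; it differs from compound 3 in one place: isopropylsulfonyl in place of (2-fluoroethoxy)carbonyl on an amine nitrogen in a ring. Within the data shown here, only one measured step touches the same amine nitrogen in a ring: a number 5 percentage points lower from compound 1 to compound 3 (within the scatter). The other step, a number 43 percentage points higher from compound 1 to compound 2 (beyond the scatter), alters a different part of the shared core and says nothing about this position. Among the measured compounds shown here, because the one relevant step, a number 5 percentage points lower from compound 1 to compound 3 (within the scatter), stayed within the scatter, for compound 4 a step within the scatter is expected, a number 2 percentage points higher from compound 3 to compound 4 (within the scatter). Compound 4 is therefore estimated at 88%, with a range from 70% to 110%.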

Compound 4, largest response reached (reported as percent of maximum), in percent of the reference or control that the assay uses: 62%
For compound 4 the middle estimate is 26 percentage points above the measured one; the measured number lies below the stated range.
By their numbers in this assay, from the lowest: compound 4; then compounds 3 and 1 (each within the scatter of the next); then compound 2.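

This amine nitrogen is not indifferent to what it carries: isopropylsulfonyl in place of (2-fluoroethoxy)carbonyl gives a number 24 percentage points lower from compound 3 to compound 4 (beyond the scatter) and in place of isopropoxycarbonyl gives a number 29 percentage points lower from compound 1 to compound 4 (beyond the scatter) in the maximal response. Among these compounds, the one earlier change here kept the carbonyl and stayed within the scatter, whereas this first replacement of the carbonyl goes beyond it. The groups leaving compound 3 and entering compound 4 match in heavy-atom and hydrogen-bond acceptor counts, so those counts do not separate them.

As far as these compounds go, whether an acetyl group or a urea on this nitrogen would match the carbonyl or the sulfonyl compounds stays open, as does whether the drop holds with the nitrile of compound 2. Nothing measured here explains the drop.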